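The compounds below may be only part of what the source reports. "The series", "measured", "known", "first", "only" and "open" are said of these compounds alone.

Measured so far:
compound 1, `Cn1ncc(Cl)c1-c1cc(C(=O)N[C@H]2CNCC[C@@H]2c2ccc(C(F)(F)F)cc2)oc1Cl`, 1050 nM
compound 2, `Cn1ncc(Cl)c1-c1cc(C(=O)N[C@@H]2CN[C@H](CC(=O)NCC(O)CO)C[C@H]2c2ccc(Cl)c(Cl)c2)oc1Cl`, 7090 nM
compound 3, `Cn1ncc(Cl)c1-c1cc(C(=O)N[C@@H]2CN[C@H](CCNS(C)(=O)=O)C[C@H]2c2ccc(F)c(F)c2)oc1Cl`, 920 nM

These three compounds share one core and were tested in a functional assay on HCT-116 cells (Homo sapiens) for antiproliferative activity, read by sulforhodamine B assay, with a stated time of 72 h; on this read-out lower numbers stand for stronger inhibition and higher numbers for weaker inhibition. Among them compound 2 gives the highest number, 7090 nM, which makes it the least potent of the three: compound 1 stands at 1050 nM and compound 3 at 920 nM, and both of those gaps lie beyond the usual scatter. Compound 4, `Cn1ncc(Cl)c1-c1cc(C(=O)N[C@@H]2CN[C@H](CCCO)C[C@H]2c2ccc(Cl)c(Cl)c2)oc1Cl`, has not yet been measured. It differs from compound 2 in one place: 2-hydroxyethyl in place of (2,3-dihydroxypropyl)carbamoyl on a saturated chain carbon bound to a saturated ring carbon. Going by the values given here, no step between measured compounds matches this change directly, so the expectation rests on the standing of compound 2 alone. Because compound 2 gives 7090 nM, the weakest number of the set, a shortening of the chain at that position is expected to bring a moderate step toward stronger inhibition, a 2.8-fold lower number from compound 2 to compound 4 (0.45 log units; beyond the scatter), rather than none. Compound 4 is therefore estimated at 2500 nM in this assay, with a plausible range from 800 nM to 8000 nM.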

Compound 4, half-maximal inhibitory concentration: 510 nM
Compound 4: middle estimate off by 4.9-fold (0.69 log units), on the high side; measured number outside the range, below it.
By their numbers in this assay, from the lowest: compounds 4, 3 and 1 (each within the scatter of the next, the first and the last beyond it); then compound 2.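

In this assay, exchanging (2,3-dihydroxypropyl)carbamoyl for 2-hydroxyethyl on a saturated chain carbon bound to a saturated ring carbon gives a 14-fold lower number from compound 2 to compound 4 (1.14 log units; beyond the scatter), so activity depends strongly on the group at this position. Only this one place differs, which ties the high number of compound 2 to this group and not to the shared core or the rest of the molecule. No measurement here explains the step.

One exchange removes the carbonyl, the amide nitrogen and both extra hydroxyl-bearing carbons' worth of the diol together, so the compounds shown cannot say which of these parts matters. On these data alone, how an amine, a carboxylic acid or a longer chain ending in a hydroxyl group would stand at this position in this assay also remains open.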